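The compounds below may be only part of what the source reports. "The series", "measured", "known", "first", "only" and "open" are said of these compounds alone.

Measured so far in a functional assay on HEK293 cells for agonist activity at Toll-like receptor 8 (Homo sapiens), read by reporter gene assay; on this read-out higher numbers stand for an effect only at larger amounts of compound and lower numbers for an effect already at smaller amounts:
- compound 2 `CCCCNc1oc2c(C)ncc(CO)c2c1Nc1ccccn1`: 9380 nM
- compound 3 `Cc1ncc(CO)c2c(Nc3ccccn3)c(NC[Si](C)(C)C)oc12`: 4990 nM
- compound 1 `Cc1ncc(CO)c(-c2nc3ccccn3c2NC2CCCCC2)c1OCc1ccccc1`: "not active" (no number reported)

Compound 2 gives the highest of the two numbers in this assay, with compound 3 nearest: the step of a 1.9-fold lower number from compound 2 to compound 3 (0.27 log units; within the scatter) lies within the scatter, so the two compounds cannot be ranked against each other. Among the compounds with values here, compound 1, built on a different core, is recorded as not active without a number and offers no step to either of the others.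

Compound 4 `Cc1ncc(CO)c2c(Nc3ccccn3)c(NC(C)(C)CC(C)(C)C)oc12` is to be measured in this assay. It differs from compound 2 by 1,1,3,3-tetramethylbutyl in place of butyl on a nitrogen on an aromatic ring. Within the data shown here, the only measured step that bears on this position is the one from compound 2 to compound 3, where a group of four heavy atoms replaced the butyl on the same nitrogen and the number moved within the scatter. Among the measured compounds shown here, no measured pair covers a branched group of this size on that nitrogen, so the direction of the step is open. Given that the one change at this position stayed within the scatter, the step of a 1.3-fold lower number from compound 2 to compound 4 (0.13 log units; within the scatter) is expected to be small. Compound 4 is therefore estimated at 7000 nM, with a range from 2000 nM to 25000 nM.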

Compound 4, half-maximal effective concentration: "not active" (no number reported)
No number was reported for compound 4; there is nothing to compare the estimate with.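

In this assay compound 4 gives "not active" (no number reported), so no step can be read from compound 2 or compound 3 to compound 4. No available evidence accounts for this result. The compounds shown leave open whether the branching or the larger count of carbons in 1,1,3,3-tetramethylbutyl sets compound 4 apart from compound 2.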